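The compounds below may be only part of what the source reports. "The series", "measured", "known", "first", "only" and "open" are said of these compounds alone.

In a physicochemical assay for solubility, measured as kinetic solubility (on this read-out lower numbers stand for lower solubility and higher numbers for higher solubility), compound 1 `CN1CCC(c2ccc(OCc3ccccc3)c(C(=O)Nc3ccnnc3)c2)CC1` gives 71000 nM as its reading. Compound 2 `O=C(Nc1ccnnc1)c1cc(N2CCCC2)ccc1OCc1ccccc1` gives 35000 nM as its reading, and a 2.0-fold lower number from compound 1 to compound 2 (0.31 log units; beyond the scatter) is a modest step. Compound 3 `N#CC1CCN(c2ccc(OCc3ccccc3)c(C(=O)Nc3ccnnc3)c2)CC1` reports < 1000 nM and that is a limit, not a number. Compound 4 `O=C(Nc1ccnnc1)c1cc(N2CCC(CO)CC2)ccc1OCc1ccccc1` carries hydroxymethyl in place of cyano on a saturated ring carbon, the change hydroxymethyl in place of cyano on a saturated ring carbon and it has not yet been measured. Among the compounds with values here, no measured step makes this exchange. The nearest are an at least 71-fold lower number from compound 1 to compound 3 (1.85 log units; beyond the scatter) and an at least 35-fold lower number from compound 2 to compound 3 (1.54 log units; beyond the scatter) and both are large, ending at the limit of < 1000 nM in this assay, at which 1 of the 3 values shown sits, in the case of compound 3. With the cyano group gone, a large move toward higher numbers is expected, estimated as an at least 10-fold higher number from compound 3 to compound 4 (1.00 log units; beyond the scatter) in this account. Compound 4 is estimated at 10000 nM within a range of 2000 nM to 40000 nM on this read-out.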

Compound 4, solubility: 323000 nM
Compound 4: the middle estimate sits 32-fold (1.51 log units) below what was measured; the measured number lies above the stated range.
By their numbers in this assay, from the lowest: compound 2; then compound 1; then compound 4. At a limit, below all of these: compound 3.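

In this assay hydroxymethyl in place of cyano gives an at least 320-fold higher number from compound 3 to compound 4 (2.50 log units; beyond the scatter) and so shows that the group on this saturated ring carbon can carry the reading far upward as well as down. The reading with 4-(hydroxymethyl)piperidin-1-yl also passes those with pyrrolidin-1-yl and 1-methylpiperidin-4-yl, with a 9.2-fold higher number from compound 2 to compound 4 (0.97 log units; beyond the scatter) and a 4.5-fold higher number from compound 1 to compound 4 (0.66 log units; beyond the scatter). Compound 3 stands at a limit and not at a number: the limit of < 1000 nM in this assay, at which 1 of the 4 values shown sits.

As far as these compounds go, the full size of the step from cyano stays open. So does whether hydroxymethyl is unusual here: a methoxymethyl, aminomethyl or carboxylic acid group on the same ring carbon would test that.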